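The compounds below may be only part of what the source reports. "The series", "measured", "known", "first", "only" and "open" are said of these compounds alone.

Compound 2 `COc1cc(C)c(S(=O)(=O)N(C)CCOCC(=O)N2CCC(C(C)(C)CN(C)C)CC2)c(C)c1` gives 10 nM in an assay on HEK293 cells for displacement of a labelled ligand from B1 bradykinin receptor (Homo sapiens), read by scintillation counting (a lower number here means a stronger inhibitor, a higher number a weaker inhibitor), the highest of the two numbers measured; its nearest neighbour, compound 1 `COc1cc(C)c(S(=O)(=O)N(C)CCOCC(=O)N2CCC(C3CCN(C)CC3)CC2)c(C)c1`, gives 0.7 nM. Among the compounds with values here, the one measured step, a 14-fold higher number from compound 1 to compound 2 (1.15 log units; beyond the scatter), shows that exchanging a ring-bound amine for an open-chain one raised the number. Compound 3 `COc1cc(C)c(S(=O)(=O)N(C)CCOCC(=O)N2CCC(N3CCN(C(C)C)CC3)CC2)c(C)c1` differs from compound 2 by 4-isopropylpiperazin-1-yl in place of 1-((dimethylamino)methyl)-1-methylethyl on a saturated ring carbon, on a saturated ring carbon of a six-membered non-aromatic ring with 1 nitrogen. Since a ring-bound amine again enters, compound 3 is expected to move back toward compound 1, with a step of a 4.0-fold lower number from compound 2 to compound 3 (0.60 log units; beyond the scatter). Compound 3 is therefore estimated at 2.5 nM, between 0.6 nM and 10 nM.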

Compound 3, inhibition constant: 3.8 nM
Compound 3: middle estimate off by 1.5-fold (0.18 log units), on the low side; measured number inside the range.
By their numbers in this assay, from the lowest: compound 1; then compound 3; then compound 2.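

In this assay, a ring-bearing amine again gives the lower number on this saturated ring carbon, with a 2.6-fold lower number from compound 2 to compound 3 (0.42 log units; beyond the scatter) when 4-isopropylpiperazin-1-yl replaces the open-chain group. A ring-bearing amine alone does not bring the number back to that of compound 1: replacing 1-methylpiperidin-4-yl with 4-isopropylpiperazin-1-yl gives a 5.4-fold higher number from compound 1 to compound 3 (0.73 log units; beyond the scatter), so the two ring groups are not interchangeable. Nothing available here explains either step. The compounds shown leave open whether the second step follows from the isopropyl group or from the piperazine ring, which 4-methylpiperazin-1-yl on the same carbon could separate.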